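Side-chain amine variation and antiproliferative potency

The source may report more compounds than this note shows. Statements on the series, on what has been measured and on what is new or still open speak of the compounds shown alone.

Measured compounds:
compound 1 `CCN(CC)CCn1c(N)c(-c2nc3ccccc3[nH]2)c2nc(C#N)c(C#N)nc21`: > 50000 nM in a functional assay on A549 cells (Homo sapiens) for antiproliferative activity, read by MTT assay, with a stated time of 48 h (a higher number here means a weaker inhibitor, a lower number a stronger inhibitor), a limit of the assay rather than a number.
compound 2 `CN1CCN(CCCn2c(N)c(-c3nc4ccccc4[nH]3)c3nc(C#N)c(C#N)nc32)CC1`: 5750 nM.
compound 3 `N#Cc1nc2c(-c3nc4ccccc4[nH]3)c(N)n(CCCO)c2nc1C#N`: > 50000 nM, again a limit of the assay.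

Compound 1 stands only at a limit in this assay, and so does compound 3: the limit of > 50000 nM in this assay, at which 2 of the 3 values shown sit. The step between them is therefore a step that the two limits leave unreadable from compound 1 to compound 3. Against compound 2 the comparison is readable: an at least 8.6-fold lower number from compound 1 to compound 2 (0.93 log units; beyond the scatter), and in the reverse sense an at least 8.6-fold higher number from compound 2 to compound 3 (0.93 log units; beyond the scatter). Only compound 2, with the (4-methylpiperazin-1-yl)methyl group, gives a number; the two open-chain or hydroxy-terminated analogues do not.

Compound 4 `N#Cc1nc2c(-c3nc4ccccc4[nH]3)c(N)n(CCCN3CCCCC3)c2nc1C#N` has not been measured. It differs from compound 1 by (piperidin-1-yl)methyl in place of diethylamino on a saturated chain carbon, two bonds along the chain from an aromatic nitrogen. Within the data shown here, the one step that bears on this change is an at least 8.6-fold lower number from compound 1 to compound 2 (0.93 log units; beyond the scatter), where a cyclic amine also replaced diethylamino at the same place. Compound 4 carries a cyclic amine on the same three-carbon chain, so a step of the same direction and roughly the same size is expected, an at least 6.2-fold lower number from compound 1 to compound 4 (0.79 log units; beyond the scatter), although a value at the limit, as for compound 1, cannot be excluded. Compound 4 is thus estimated at 8000 nM, with a range of 2000 nM to 50000 nM.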

Compound 4, half-maximal inhibitory concentration: 6110 nM
Compound 4: middle estimate off by 1.3-fold (0.12 log units), on the high side; low and high end bracket the measured number.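

In this assay, a second cyclic amine on the propyl chain also gives a number rather than a limit, so compound 2 no longer stands alone, and the result holds for piperidin-1-yl as well as 4-methylpiperazin-1-yl: an at least 8.1-fold lower number from compound 1 to compound 4 (0.91 log units; beyond the scatter), and an at least 8.1-fold lower number from compound 3 to compound 4 (0.91 log units; beyond the scatter). The two cyclic amines are not separated, with a 1.1-fold higher number from compound 2 to compound 4 (0.03 log units; within the scatter), so within these compounds the methyl-bearing second ring nitrogen of compound 2 is not required for a value in this range. The steps from compound 1 and compound 3 give only a minimum size, and the step between those two cannot be read: the limit of > 50000 nM in this assay, at which 2 of the 4 values shown sit.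

Compound 1 carries 2-(diethylamino)ethyl and compound 4 carries 3-(piperidin-1-yl)propyl, so the ring and the chain length change together, and only a 3-(diethylamino)propyl or a 2-(piperidin-1-yl)ethyl analogue could separate the two. Also open, from the compounds shown here alone, is whether other terminal groups, such as morpholin-4-yl or pyrrolidin-1-yl, or a butyl chain carrying piperidin-1-yl, would leave the number unchanged or move it beyond the scatter.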